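The compounds below may be only part of what the source reports. "The series", "measured", "known", "first", "only" and "open" are said of these compounds alone.

Measured so far in a functional assay on RBL-2H3 cells (Rattus norvegicus) for inhibition, with stated times of 30 min and 1 h; on this read-out higher numbers stand for weaker inhibition and lower numbers for stronger inhibition:
- Compound 1 `COc1ccc(CN(CCN(C)C)c2ccccc2)cc1` gives 243 nM
- Compound 2 `COc1ccc(CN(CCN(C)C)c2ccc(N)cc2)cc1` gives 4060 nM

Compound 2 has the higher of the two numbers, which makes it the weaker inhibitor of the pair. The next compound, compound 3 `COc1ccc(CN(CCN(C)C)c2ccc(C)cc2)cc1`, differs from it in one place: methyl in place of amino on an aromatic carbon. This puts methyl in place of amino on an aromatic carbon, para to a large group. Within the data shown here, only one measured step bears on this change, and it is large and beyond the scatter: a 17-fold higher number from compound 1 to compound 2 (1.22 log units; beyond the scatter). Among the measured compounds shown here, that step put amino in place of hydrogen, and no methyl compound has been measured yet. With the amino gone, a large downward step is expected in this assay, back towards compound 1 at 243 nM, though probably not all the way. The expected step is a 10-fold lower number from compound 2 to compound 3 (1.01 log units; beyond the scatter). For compound 3 the estimated value is 400 nM, with an expected range of 130 nM to 1300 nM.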

Compound 3, half-maximal inhibitory concentration: 89.1 nM
The estimate for compound 3 lay 4.5-fold (0.65 log units) above the measured number; measured number below the stated range.
By their numbers in this assay, from the lowest: compound 3; then compound 1; then compound 2.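

In this assay, the position on the aromatic ring accepts a group without loss, since adding methyl gives a 2.7-fold lower number from compound 1 to compound 3 (0.44 log units; beyond the scatter). The earlier drop therefore goes with amino specifically and not with any group placed here, and the exchange of amino for methyl gives a 46-fold lower number from compound 2 to compound 3 (1.66 log units; beyond the scatter), a much larger change than the step from hydrogen to methyl. Amino brings a hydrogen-bond donor and acceptor and methyl brings neither, but no measurement here shows whether that count accounts for the gap or why the two groups differ.

On these data alone, with only hydrogen, amino and methyl at this position, it remains open whether a longer chain such as ethyl would extend the gain seen with methyl. As far as these compounds go, it is equally open how a chlorine atom, a hydroxyl or a methoxy group would compare.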